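Triazolyl to imidazolyl exchange in compound 2

This account rests on a few compounds, and the source may have more. Where it says the series, first, only, none or still open, it means among the compounds named here.

Compound 1 `CN1CCN(c2ccc(C3=NNC(c4ccc(N(C)C)cc4)C3)cc2)CC1` and compound 2 `CN(C)c1ccc(C2CC(c3ccc(-n4cncn4)cc3)=NN2)cc1` share one core and differ at a single aromatic carbon, where 1H-1,2,4-triazol-1-yl replaces 4-methylpiperazin-1-yl. In a functional assay on NCI-H1975 cells (Homo sapiens) for inhibition, read by sulforhodamine B assay, tested at 10 uM (a lower number here means less inhibition, a higher number more inhibition at the concentration tested (going by the name of the read-out)), compound 1 gives 2.4% and compound 2 gives -3.3%; the step of a number 5.7 percentage points lower from compound 1 to compound 2 (within the scatter) is within the scatter. Compound 2 is the lower of the two numbers on paper, but its gap to compound 1 is within the scatter, so neither stands apart. Compound 3 `CN(C)c1ccc(C2CC(c3ccc(-n4ccnc4)cc3)=NN2)cc1` is not yet measured; its change from compound 2 is 1H-imidazol-1-yl in place of 1H-1,2,4-triazol-1-yl on an aromatic carbon, on an aromatic carbon of a six-membered aromatic ring of carbon only, para to a large group. For the measured compounds named here, the single measured step, a number 5.7 percentage points lower from compound 1 to compound 2 (within the scatter), is the only one that touches this position and showed nothing beyond the scatter; no step compares two azoles. With compound 1 at 2.4% and compound 2 at -3.3%, both near zero, the expected step of a number 3.3 percentage points higher from compound 2 to compound 3 (within the scatter) is none beyond the scatter. Compound 3 is therefore estimated at 0% in this assay, within -10% to 10%.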

Compound 3, a percentage reported as inhibition, at one concentration (the size of the read-out at that concentration, not a potency): 0.1%
Compound 3: middle estimate off by 0.1 percentage points, on the low side; low and high end bracket the measured number.
By their numbers in this assay, from the lowest: compounds 2, 3 and 1 (each within the scatter of the next).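

In this assay, 1H-imidazol-1-yl in place of 1H-1,2,4-triazol-1-yl gives a number 3.4 percentage points higher from compound 2 to compound 3 (within the scatter). For the compounds shown here, this is the first direct comparison of two azoles on this aromatic carbon, para to a large group, and the two azoles cannot be told apart. With a number 2.3 percentage points lower from compound 1 to compound 3 (within the scatter) as well, 4-methylpiperazin-1-yl, 1H-1,2,4-triazol-1-yl and 1H-imidazol-1-yl all lie within the scatter of one another, and no measurement available offers an explanation for these numbers.

The compounds shown leave open whether this position is insensitive to its substituent or the shared core gives too little signal in this assay for any difference to appear. A carboxylic acid or a primary amine on the same aromatic carbon would test whether any group here moves the number beyond the scatter.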